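Relocating the chlorine on the shared core

The compounds below may be only part of what the source reports. "The series", "measured", "known", "first", "only" and "open" are said of these compounds alone.

Compound 1 `Oc1cccc(-c2cc(-c3cccnc3)nc(-c3cccc(Cl)c3)c2)c1` is tested in an assay on isolated protein for inhibition of DNA topoisomerase 1 (Homo sapiens), with a stated time of 30 min, tested at 100 uM (on this read-out lower numbers stand for a weaker effect and higher numbers for a stronger effect at the one concentration tested), where compound 1 gives 27.6%. Compound 2 `Oc1ccc(-c2cc(-c3cccc(Cl)c3)nc(-c3ccccn3)c2)cc1` gives 59.4% in this assay, so compound 1 stands as the lower of the two numbers, with a gap beyond the usual scatter. Compound 3 `Oc1cccc(-c2cc(-c3ccc(Cl)cc3)nc(-c3cccnc3)c2)c1` has not yet been measured; it differs from compound 1 by 4-chlorophenyl in place of 3-chlorophenyl on an aromatic carbon. Among the measured compounds shown here, no single-change step between measured compounds is available, so the step in this assay is expected to be small, without a clear direction beyond the scatter. Compound 3 is therefore expected to give 30% in this assay, between 15% and 50%. The expected step is a number 2.4 percentage points higher from compound 1 to compound 3 (within the scatter).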

Compound 3, a percentage reported as inhibition, at one concentration (the size of the read-out at that concentration, not a potency): 2.8%
For compound 3 the middle estimate is 27.2 percentage points above the measured one; the whole stated range lies above it.
By their numbers in this assay, from the lowest: compound 3; then compound 1; then compound 2.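

In this assay, shifting the chlorine from 3-chlorophenyl to 4-chlorophenyl, on the aromatic carbon next to the ring nitrogen, gives a number 24.8 percentage points lower from compound 1 to compound 3 (beyond the scatter). With the same atoms on both sides, the read-out at this position thus depends on where the chlorine sits on the phenyl ring, which the earlier pair, differing in more than one place, could not show. No evidence at hand accounts for this step. On these data alone, it remains open how a 2-chlorophenyl group, or an amine in place of the chlorine, would read here, and whether the same shift would act alike on the core of compound 2.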